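The source may hold more compounds than are shown below. What is called first, only, known or untested is meant among the compounds shown, and "the series" means these compounds.

In a functional assay on MCF7 cells (Homo sapiens) for inhibition, read by MTT assay (on this read-out higher numbers stand for weaker inhibition and lower numbers for stronger inhibition), three amides sharing one core have been measured. Compound 1 (`COc1cc2ncnc(Nc3ccc(NC(=O)c4ccccc4C)cc3)c2cc1OC`) gives 21000 nM, compound 2 (`COc1cc2ncnc(Nc3ccc(NC(=O)c4cccc(C)c4)cc3)c2cc1OC`) gives 13000 nM, and compound 3 (`COc1cc2ncnc(Nc3ccc(NC(=O)c4ccccc4F)cc3)c2cc1OC`) gives 11000 nM. The steps reaching compound 3 are a 1.9-fold lower number from compound 1 to compound 3 (0.28 log units; within the scatter) and a 1.2-fold lower number from compound 2 to compound 3 (0.07 log units; within the scatter), so it cannot be ranked against either neighbour. Compound 4 (`COc1cc2ncnc(Nc3ccc(NC(=O)c4cccc(F)c4)cc3)c2cc1OC`) has not yet been measured. It differs from compound 3 in a single place: 3-fluorophenyl in place of 2-fluorophenyl on a carbonyl carbon. The fluoro group therefore stays, but the ring changes from 2-fluorophenyl to 3-fluorophenyl. The closest parallel is the matching methyl change, 3-methylphenyl in place of 2-methylphenyl on a carbonyl carbon, which gave a 1.6-fold lower number from compound 1 to compound 2 (0.21 log units; within the scatter). For the measured compounds named here, that is only one example, and it offers no firm direction, so no step beyond the scatter is expected in this assay. The estimated change is a 1.1-fold lower number from compound 3 to compound 4 (0.04 log units; within the scatter). The expected value for compound 4 is 10000 nM, with an estimated range from 5000 nM to 22000 nM.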

Compound 4, half-maximal inhibitory concentration: 13600 nM
Beside the measured number, compound 4's estimate is 1.4-fold (0.13 log units) below it; the measured number falls inside the stated range.
By their numbers in this assay, from the lowest: compounds 3, 2, 4 and 1 (each within the scatter of the next).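

In this assay, 3-fluorophenyl in place of 2-fluorophenyl on the carbonyl carbon gives a 1.2-fold higher number from compound 3 to compound 4 (0.09 log units; within the scatter), so this change of the fluoro group's place on the ring now has a direct reading, and it does not separate the two compounds. The other two new steps, a 1.0-fold higher number from compound 2 to compound 4 (0.02 log units; within the scatter) and a 1.5-fold lower number from compound 1 to compound 4 (0.19 log units; within the scatter), also stay within the scatter, so none of the four amides can be ranked against another. Fluoro in place of methyl can now be read on two pairs, and the two readings do not differ beyond what repeat measurements would allow: the same change on two cores in this assay, a 1.9-fold lower number (0.28 log units; within the scatter) from compound 1 to compound 3 and a 1.0-fold higher number (0.02 log units; within the scatter) from compound 2 to compound 4, 2.0-fold (0.30 log units) apart, within the scatter of two such steps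

From the compounds shown here alone, the ring in these compounds carries only methyl or fluoro, so whether any group here can shift the number beyond the scatter remains open. A carboxylic acid or an amine on this ring would be a much sharper test of that.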